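The source may hold more compounds than are shown below. What is called first, only, known or untested is meant among the compounds shown, and "the series" means these compounds.

Measured so far:
- compound 1, `CCNc1nc(-c2ccccc2)nc2c1nnn2Cc1ccccc1F`, 11000000 nM
- compound 2, `CNc1nc(-c2ccccc2)nc2c1nnn2Cc1ccccc1F`, 25000000 nM
- compound 3, `CCCNc1nc(-c2ccccc2)nc2c1nnn2Cc1ccccc1F`, 3200000 nM

In an assay on isolated protein for binding affinity to adenosine receptor A1 (Bos taurus) (on this read-out higher numbers stand for weaker inhibition and lower numbers for stronger inhibition), compound 3 stands lowest of the three. The steps all point one way: a 2.3-fold higher number from compound 1 to compound 2 (0.36 log units; beyond the scatter), a 3.4-fold lower number from compound 1 to compound 3 (0.54 log units; beyond the scatter) and a 7.8-fold lower number from compound 2 to compound 3 (0.89 log units; beyond the scatter), so a longer chain on the ring nitrogen has gone with a lower number each time. Compound 4, `Fc1ccccc1Cn1nnc2c(NC3CC3)nc(-c3ccccc3)nc21`, differs from compound 3 by cyclopropyl in place of propyl on a nitrogen on an aromatic ring. Going by the values given here, the entering group carries the same count of carbons as the one it replaces, so the measured steps bear only loosely; no step shows a ring in this place. A change no larger than the scatter is expected, with a slight lean downward: for compound 4 the estimate is 2000000 nM, range 600000 nM to 6500000 nM, meaning an expected step of a 1.6-fold lower number from compound 3 to compound 4 (0.20 log units; within the scatter).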

Compound 4, inhibition constant: 15000000 nM
The estimate for compound 4 lay 7.5-fold (0.88 log units) below the measured number; measured number outside the range, above it.
By their numbers in this assay, from the lowest: compound 3; then compounds 1, 4 and 2 (each within the scatter of the next, the first and the last beyond it).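

In this assay the same three carbons do not give the same number once they are closed into a ring: going from propyl to cyclopropyl gives a 4.7-fold higher number from compound 3 to compound 4 (0.67 log units; beyond the scatter) on this nitrogen. The ring instead sits level with the shorter chains, with a 1.7-fold lower number from compound 2 to compound 4 (0.22 log units; within the scatter) against methyl and a 1.4-fold higher number from compound 1 to compound 4 (0.13 log units; within the scatter) against ethyl, so carbon count alone does not set the number here. Nothing measured here says why ring and chain differ.

Still open, from the compounds shown here alone, is whether a longer chain such as butyl would bring the number down further, and whether a larger ring such as cyclopentyl would track cyclopropyl or the chains.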